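This account rests on a few compounds, and the source may have more. Where it says the series, first, only, none or still open, it means among the compounds named here.

Compound 1 `Fc1cccc(F)c1Cn1c(-c2c(F)cccc2F)nc2cnccc21` sets the tone of the series. In an ADME assay on MDBK cells (Bos taurus) for cytotoxicity (a lower number here means that less compound is tolerated, a higher number that more compound is tolerated), compound 1 gives > 100000 nM, which is a limit of the assay and not a number. Compound 2 `Clc1cccc(Cn2ccc3nc(-c4ccccc4)nc-3c2)c1` behaves the same way: in this assay compound 2 gives > 100000 nM, again a limit and not a number. Going by the values given here, compound 3 `FC(F)(F)c1cccc(Cn2ccc3nc(-c4ccccc4)nc-3c2)c1` is the only member with a measured number: in this assay compound 3 gives 98000 nM. Among the compounds with values here, the single step between measured compounds, trifluoromethyl in place of chloro on an aromatic carbon, came out as an at least 1.0-fold lower number from compound 2 to compound 3 (0.00 log units; that floor lies within the scatter); this is governed by the limit of > 100000 nM in this assay, at which 2 of the 3 values shown sit, so it tells only that the two compounds are equally well tolerated as far as the assay can see.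

Compound 2 therefore stands on a limit alone, and one further value shown is also a limit; no number places it within the series.

Compound 4 `CCn1ccc2nc(-c3ccccc3)nc-2c1` differs from compound 2 by methyl in place of 3-chlorophenyl on a saturated chain carbon bound to an aromatic nitrogen. Within the data shown here, no measured step removes the 3-chlorophenyl; the only step available kept that ring and moved nothing beyond the scatter. For compound 4 the expectation is a step of a number no higher from compound 2 to compound 4 (the limit leaves the size open), that is, none beyond the scatter. Compound 4 is accordingly estimated at 100000 nM, between 50000 nM and 300000 nM, most probably reported again as a limit.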

Compound 4, half-maximal cytotoxic concentration: > 100000 nM
Compound 4 gave a limit, no number; the forecaster's own chance of this, stated with the estimate: 70%; the middle value sits exactly at the limit.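

In this assay compound 4 gives > 100000 nM, a limit and not a number. Compound 2 also stands on a limit, so no step between compound 2 and compound 4 can be read: the limit of > 100000 nM in this assay, at which 3 of the 4 values shown sit.

Still open, on these data alone, is how much compound is tolerated by compound 2 and compound 4, and whether methyl in place of 3-chlorophenyl changes it at all.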